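The compounds below may be only part of what the source reports. "The series", "measured", "known", "first", "only" and "open" are said of these compounds alone.

In a functional assay on HT-29 cells (Homo sapiens) for cytotoxicity, read by MTT assay, with a stated time of 72 h (on this read-out higher numbers stand for weaker inhibition and lower numbers for stronger inhibition), compound 1 `COc1cc2c(Oc3ccc(NC(=O)c4cc(-c5ccccc5)ccn4)cc3F)ccnc2cc1OCCCN1CCN(C)CC1` gives 82 nM, compound 2 `COc1cc2c(Oc3ccc(NC(=O)c4cc(-c5ccc(F)cc5)ccn4)cc3F)ccnc2cc1OCCCN1CCCCC1` gives 1370 nM and compound 3 `COc1cc2c(Oc3ccc(NC(=O)c4cc(-c5ccccc5C)ccn4)cc3F)ccnc2cc1OCCCN1CCN(C)CC1` gives 180 nM. Compound 3 thus holds the second highest of the three numbers, with compound 1 nearest and compound 2 furthest. For the measured compounds named here, the only single-place step measured so far, a 2.2-fold higher number from compound 1 to compound 3 (0.34 log units; beyond the scatter), is modest. Compound 4 `COc1cc2c(Oc3ccc(NC(=O)c4cc(-c5ccc(F)cc5)ccn4)cc3F)ccnc2cc1OCCCN1CCN(C)CC1` differs from compound 3 by 4-fluorophenyl in place of 2-methylphenyl on an aromatic carbon. Going by the values given here, no measured step covers a fluorine on this ring with the methylpiperazine chain in place; compound 2 carries the same 4-fluorophenyl on a different amine and shows a high number, which cannot be separated into its two parts here. The change to compound 4 is expected to roughly undo a 2.2-fold higher number from compound 1 to compound 3 (0.34 log units; beyond the scatter), amounting to a 1.2-fold lower number from compound 3 to compound 4 (0.08 log units; within the scatter) in this assay. Compound 4 is therefore estimated at 150 nM, between 50 nM and 450 nM.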

Compound 4, half-maximal inhibitory concentration: 1460 nM
Compound 4: middle estimate off by 9.7-fold (0.99 log units), on the low side; the measured number lies above the stated range.
By their numbers in this assay, from the lowest: compound 1; then compound 3; then compounds 2 and 4 (each within the scatter of the next).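

In this assay, a fluoro on the phenyl ring at this position, opposite the ring nitrogen, carries a large penalty (an 18-fold higher number from compound 1 to compound 4 (1.25 log units; beyond the scatter)). Against 2-methylphenyl the same group also loses ground (an 8.1-fold higher number from compound 3 to compound 4 (0.91 log units; beyond the scatter)). With 4-fluorophenyl in place, 4-methylpiperazin-1-yl and piperidin-1-yl are not told apart (a 1.1-fold higher number from compound 2 to compound 4 (0.03 log units; within the scatter)), so the high number of compound 2 no longer points to its amine.

Open, going by these compounds, is whether 4-chlorophenyl, 4-methoxyphenyl or 2-fluorophenyl at this position follows 4-fluorophenyl or 2-methylphenyl. No measured evidence accounts for the penalty.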